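Difluorophenyl for Nitrophenyl: Cytotoxicity Held at the Limit

The source may report more compounds than this note shows. Statements on the series, on what has been measured and on what is new or still open speak of the compounds shown alone.

Compound 1 `CCOC(=O)c1cc(-c2cccc(OCc3cccc([N+](=O)[O-])c3)c2)on1`: > 128000 nM, a limit of the assay rather than a number.
Compound 2 `CCOC(=O)c1ccc(COc2cccc(-c3cc(C(=O)OCC)no3)c2)cc1`: > 128000 nM, likewise a limit of the assay.

Both measured compounds share a core carrying an ester and a phenyl ether; they differ only in the aromatic group on the saturated chain carbon bound to the ether oxygen. On these data alone, in an ADME assay on Vero cells (Chlorocebus sabaeus) for cytotoxicity, with a stated time of 72 h (on this read-out higher numbers stand for weaker inhibition and lower numbers for stronger inhibition), compound 1 reaches only the assay's limit, so its true value is unknown. Compound 2 sits at the same limit in this assay. This is the whole picture so far: the limit of > 128000 nM in this assay, at which 2 of the 2 values shown sit. Among the measured compounds shown here, because of the limit of > 128000 nM in this assay, at which 2 of the 2 values shown sit, compound 1 cannot be placed anywhere except at that ceiling, and no step between measured compounds is available.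

The unmeasured compound 3 `CCOC(=O)c1cc(-c2cccc(OCc3ccc(F)c(F)c3)c2)on1` keeps the core and changes the outer ring: 3,4-difluorophenyl in place of 3-nitrophenyl on a saturated chain carbon bound to an oxygen on an aromatic ring. Nothing measured speaks for a change in cytotoxicity, so the step of a number no higher from compound 1 to compound 3 (the limit leaves the size open) is expected to be none beyond the scatter. Compound 3 is therefore expected to give about 128000 nM in this assay, somewhere between 64000 nM and 256000 nM, most likely again only as a limit.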

Compound 3, half-maximal inhibitory concentration: > 128000 nM
Compound 3: no number, only a limit; the forecaster's own chance of this, stated with the estimate: 80%; the middle value lies on the limit itself.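

No step can be read between compound 1 and compound 3, because each stops at a limit of the assay rather than a number: the limit of > 128000 nM in this assay, at which 3 of the 3 values shown sit.

The compounds shown leave open how far the true values of compound 1, compound 2 and compound 3 lie past that limit in this assay, and whether any change to the outer ring would give a readable number.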